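Cyclic versus Acyclic Amides on a Shared Sulfonamide Core

A few compounds are considered here, and "the series" means these few. Any claim that something is new, unique, unknown or untested is made for them only; others in the source may bear on it.

Compound 1 `CCN(CC)S(=O)(=O)c1ccc(S(=O)(=O)N2CCC[C@@H](C(=O)N3CCOCC3)C2)cc1` gives 350 nM in a functional assay on MIA PaCa-2 cells (Homo sapiens) for inhibition, read by MTT assay, with a stated time of 7 days; on this read-out lower numbers stand for stronger inhibition and higher numbers for weaker inhibition.
Compound 2 `CCN(CC)S(=O)(=O)c1ccc(S(=O)(=O)N2CCC[C@@H](C(=O)N[C@H]3CC[C@@H](OC)CC3)C2)cc1` gives 960 nM in this assay.

Compound 2 stands highest of the two numbers; its nearest neighbour is compound 1, at a lower number. Compound 3 `CCN(CC)S(=O)(=O)c1ccc(S(=O)(=O)N2CCC[C@@H](C(=O)N3CC[C@H](OC)C3)C2)cc1` differs from compound 2 thus: 3-methoxypyrrolidin-1-yl in place of (4-methoxycyclohexyl)amino on a carbonyl carbon. Among the measured compounds shown here, the one measured step that bears on this is a 2.7-fold higher number from compound 1 to compound 2 (0.44 log units; beyond the scatter), where the cyclic amide of compound 1 gave way to an acyclic one. Compound 3 returns to a cyclic amide, so a lowering of comparable size is expected, giving a 2.1-fold lower number from compound 2 to compound 3 (0.33 log units; beyond the scatter). Compound 3 is therefore estimated at 450 nM, within a range of 180 nM to 1100 nM.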

Compound 3, half-maximal inhibitory concentration: 2460 nM
Beside the measured number, compound 3's estimate is 5.5-fold (0.74 log units) below it; measured number above the stated range.
By their numbers in this assay, from the lowest: compound 1; then compound 2; then compound 3.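

In this assay, the change to 3-methoxypyrrolidin-1-yl on the carbonyl carbon did not lower the number but raised it, with a 2.6-fold higher number from compound 2 to compound 3 (0.41 log units; beyond the scatter). The two cyclic amides in this set also differ, with a 7.0-fold higher number from compound 1 to compound 3 (0.85 log units; beyond the scatter). A cyclic amide at this position therefore does not by itself give the lower number, and the identity of the ring matters.

Nothing measured here explains these steps. Going by these compounds, whether pyrrolidin-1-yl without the methoxy group, or piperidin-1-yl, would sit nearer morpholin-4-yl remains open.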